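A few compounds are considered here, and "the series" means these few. Any claim that something is new, unique, unknown or untested is made for them only; others in the source may bear on it.

In a physicochemical assay for solubility (a lower number here means a less soluble compound, a higher number a more soluble compound), compound 1 (`CCCC(=O)n1c(=S)[nH]c2ccccc21`) gives 190000 nM and compound 2 (`CCCCCC(=O)n1c(=S)[nH]c2ccccc21`) gives 170000 nM, so compound 2 stands level with compound 1 within the usual scatter. Compound 3 (`CCC(=O)n1c(=S)[nH]c2ccccc21`) has not yet been measured. The change from compound 2 to compound 3 is hydrogen in place of propyl on a saturated chain carbon, two bonds along the chain from a carbonyl carbon. Going by the values given here, only one measured step bears on this, ethyl in place of hydrogen on a saturated chain carbon, three bonds along the chain from a carbonyl carbon, and it came to a 1.1-fold lower number from compound 1 to compound 2 (0.05 log units; within the scatter). One small step at another chain position is thin evidence, but it gives no reason to expect a shift beyond the scatter. The expected step in this assay is a 1.2-fold higher number from compound 2 to compound 3 (0.07 log units; within the scatter). Compound 3 is estimated at 200000 nM, with an expected range of 110000 nM to 360000 nM.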

Compound 3, solubility: 180000 nM
Compound 3: middle estimate off by 1.1-fold (0.05 log units), on the high side; the range from low to high includes it.
By their numbers in this assay, from the lowest: compounds 2, 3 and 1 (each within the scatter of the next).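

In this assay the place two bonds along the chain from a carbonyl carbon now has readings of its own: hydrogen in place of propyl brings a 1.1-fold higher number from compound 2 to compound 3 (0.02 log units; within the scatter) and hydrogen in place of methyl brings a 1.1-fold lower number from compound 1 to compound 3 (0.02 log units; within the scatter) at this place. Going by these compounds alone, the earlier pair covered only a single change, whereas these two steps show that a small and a larger group can both give way to hydrogen here with no shift beyond the scatter, so all three compounds stand level. Nothing measured here offers an explanation for this result.

Going by these compounds, whether a much longer chain or a ring at this place would stay level remains open. So does the outcome for an amine or a carboxylic acid, which would bring in atoms other than carbon.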